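From Benzyl to a Fused Bicyclic Amine: Estimating Compound 4

A few compounds are considered here, and "the series" means these few. Any claim that something is new, unique, unknown or untested is made for them only; others in the source may bear on it.

Compound 1 `c1cc2cc(-c3ccc4oc(NC5CCCCC5)nc4c3)cnc2[nH]1`: > 1000 nM
Compound 2 `Cn1ccc2cc(-c3ccc4oc(Cc5ccccc5)nc4c3)ccc21`: 488 nM
Compound 3 `Cn1ccc2cc(-c3ccc4oc(N5CCN(c6ccccc6)CC5)nc4c3)ccc21`: 63 nM

Of the compounds shown here, three have been measured in an assay on HEK293 cells for inhibition of Fatty-acid amide hydrolase 1 (Homo sapiens), read by fluorescence; on this read-out higher numbers stand for weaker inhibition and lower numbers for stronger inhibition. For compound 1 the value > 1000 nM is a limit of this assay, not a number; it sits at the limit of > 1000 nM in this assay, at which 1 of the 3 values shown sits. Among the two numbers, compound 2 stands highest at 488 nM, while compound 3 gives 63 nM, a gap beyond the scatter. Compound 4 `Cn1ccc2cc(-c3ccc4oc(N5Cc6ccncc6C5)nc4c3)ccc21` differs from compound 2 in one place: a group of 9 heavy atoms (7 carbon, 2 nitrogen; one five-membered non-aromatic ring with 1 hetero atom, one six-membered aromatic ring with 1 hetero atom) in place of a group of 7 heavy atoms (7 carbon; one six-membered aromatic ring of carbon only), on an aromatic carbon. Within the data shown here, no measured pair shows this change, so the expectation rests on the shared core, where compound 3 reaches a markedly lower number than compound 2. The step of a 3.3-fold lower number from compound 2 to compound 4 (0.51 log units; beyond the scatter) is expected to lower the number, likely beyond the scatter. Compound 4 is therefore estimated at 150 nM, within a range from 40 nM to 600 nM.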

Compound 4, half-maximal inhibitory concentration: 121 nM
Compound 4: middle estimate off by 1.2-fold (0.09 log units), on the high side; the measured number falls inside the stated range.
By their numbers in this assay, from the lowest: compounds 3 and 4 (each within the scatter of the next); then compound 2. At a limit, above all of these: compound 1.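

At this aromatic carbon, next to the ring nitrogen and next to the ring oxygen, exchanging benzyl for the fused amine group gives a 4.0-fold lower number from compound 2 to compound 4 (0.61 log units; beyond the scatter) in this assay. A lower number at this position is therefore not confined to the phenyl-bearing ring of compound 3, since a smaller-looking fused group with a pyridine-type ring also reaches it. Nothing measured here explains the change.

The compounds shown leave open whether the aromatic ring nitrogen of compound 4 matters, as the same fused group with carbon there does not appear. They also leave open how a simple dimethylamine or a carboxylic acid would fare at this carbon.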